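Sulfur substituent change in a growth inhibition series

A few compounds are considered here, and "the series" means these few. Any claim that something is new, unique, unknown or untested is made for them only; others in the source may bear on it.

Measured compounds:
compound 1 `Cc1ccc(SCc2ccc(/C=C/C(=O)Nc3ccccc3N)cc2)cc1`: 22.9%
compound 2 `Cc1ccc(SCc2ccc(C(=O)Nc3ccccc3N)cc2)cc1`: 17.5%

In a functional assay on A-375 cells (Homo sapiens) for inhibition, read by CCK-8 assay, with a stated time of 72 h, tested at 2 uM (a lower number here means less inhibition of growth, a higher number more inhibition of growth at the concentration tested), compound 1 gives 22.9%. In this assay compound 2 gives 17.5%. Compound 1 gives the nearer reference point for the present step; its value and that of compound 2 lie within the usual scatter of each other, so the two are not separable on these numbers.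

Compound 3 `Nc1ccccc1NC(=O)/C=C/c1ccc(CSc2cccc3ccccc23)cc1` is not yet measured. It differs from compound 1 by naphthalen-1-yl in place of 4-methylphenyl on a sulfur. Going by the values given here, no step between measured compounds addresses this kind of change, so there is nothing in the data to support a shift in either direction. The expected step of a number 2.1 percentage points higher from compound 1 to compound 3 (within the scatter) is therefore none beyond the scatter.

For compound 3 the estimated value is 25%, with an expected range from 10% to 45%.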

Compound 3, percent growth inhibition at one concentration: 1.55%
For compound 3 the middle estimate is 23.5 percentage points above the measured one; measured number outside the range, below it.
By their numbers in this assay, from the lowest: compound 3; then compounds 2 and 1 (each within the scatter of the next).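

Naphthalen-1-yl in place of 4-methylphenyl on a sulfur brings a number 21.4 percentage points lower from compound 1 to compound 3 (beyond the scatter) in this assay and so shows that the group at this place is not interchangeable within the series. With the rest of the core of compound 1 unchanged, the second six-membered aromatic ring comes with a clear loss of growth inhibition at the concentration tested, and compound 3 gives 1.55% in this assay. No measurement at hand gives a reason for this loss.

The compounds shown leave open whether the same exchange on compound 2 would bring a similar step. They also leave open how an unsubstituted phenyl, a naphthalen-2-yl, a cyclohexyl or a 4-aminophenyl group on the same sulfur would read out, so the step cannot yet be tied to any one feature of naphthalen-1-yl.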